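Trifluoromethyl in Place of Hydroxy on the Shared Core

This account rests on a few compounds, and the source may have more. Where it says the series, first, only, none or still open, it means among the compounds named here.

Of the compounds shown here, three sharing one core have been measured in a functional assay (trachea) with Rattus norvegicus as the target; on this read-out higher numbers stand for higher potency (the scale is a negative logarithm) and lower numbers for lower potency. Compound 1 `CC1(C)C=C(n2ccccc2=O)c2cc(C(=O)c3ccccc3)ccc2O1` gives 6.21, and compound 2 `Cc1ccccc1C(=O)c1ccc2c(c1)C(n1ccccc1=O)=CC(C)(C)O2` gives 6.25; the step of a number 0.04 log units higher from compound 1 to compound 2 (within the scatter) lies within the scatter. Compound 3 `CC1(C)C=C(n2ccccc2=O)c2cc(O)ccc2O1` gives 5.31 and stands lowest of the three, with the steps of a number 0.90 log units lower from compound 1 to compound 3 (beyond the scatter) and a number 0.94 log units lower from compound 2 to compound 3 (beyond the scatter) both beyond the scatter.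

Compound 4 `CC1(C)C=C(n2ccccc2=O)c2cc(C(F)(F)F)ccc2O1` is not yet measured. It differs from compound 3 by trifluoromethyl in place of hydroxy on an aromatic carbon. Among the compounds with values here, no measured step places a trifluoromethyl at this position, so the expectation rests only on the hydroxy itself: both steps that introduced it, from compound 1 and from compound 2, lowered potency by modest amounts, and replacing it with a group that is neither donor nor acceptor is expected to recover part of that loss rather than all of it. A modest rise a number 0.49 log units higher from compound 3 to compound 4 (beyond the scatter) is therefore expected. Compound 4 is estimated at 5.8, within a range from 5.3 to 6.4.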

Compound 4, logarithm of the reciprocal of the active concentration, log(1/C): 7.37
Beside the measured number, compound 4's estimate is 1.57 log units below it; measured number above the stated range.
By their numbers in this assay, from the lowest: compound 3; then compounds 1 and 2 (each within the scatter of the next); then compound 4.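

In this assay, within the data shown here, the position on the aromatic carbon proves able to carry far more potency than the earlier compounds showed: trifluoromethyl in place of hydroxy gives a number 2.06 log units higher from compound 3 to compound 4 (beyond the scatter) and is a large step, well beyond the modest differences seen so far. Trifluoromethyl also outperforms both carbonyl groups, with a number 1.12 log units higher from compound 2 to compound 4 (beyond the scatter) and a number 1.16 log units higher from compound 1 to compound 4 (beyond the scatter) as the two steps. An aromatic ring in this substituent is therefore not needed for high potency, and compound 4, whose group has no ring and no hydrogen-bond donor or acceptor, has the highest number of the four.

As far as these compounds go, whether a nitrile, a chlorine or a pentafluoroethyl group at this position would match trifluoromethyl remains open. Nothing available accounts for the size of these steps.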